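Amide variation on the chloroquinoline-piperazine series: L6 cytotoxicity

A few compounds are considered here, and "the series" means these few. Any claim that something is new, unique, unknown or untested is made for them only; others in the source may bear on it.

Measured so far:
- compound 1, `CC(C)CC(=O)NCCCN1CCN(CCCNc2ccnc3cc(Cl)ccc23)CC1`: "not determined" (no result reported)
- compound 2, `O=C(CCCC1CCCCC1)NCCCN1CCN(CCCNc2ccnc3cc(Cl)ccc23)CC1`: "not determined" (no result reported)
- compound 3, `O=C(CCCOc1ccccc1)NCCCN1CCN(CCCNc2ccnc3cc(Cl)ccc23)CC1`: 9300 nM

In an ADME assay on L6 cells (Rattus norvegicus) for cytotoxicity (on this read-out higher numbers stand for weaker inhibition and lower numbers for stronger inhibition), compound 1 has no single number, and compound 2 likewise returns no result. Only compound 3 gives a measured value, 9300 nM, so compound 1 cannot be placed against the others on this read-out.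

Compound 4, `O=C(NCCCN1CCN(CCCNc2ccnc3cc(Cl)ccc23)CC1)c1ccc(Cl)c([N+](=O)[O-])c1`, differs from compound 1 by 4-chloro-3-nitrophenyl in place of isobutyl on a carbonyl carbon. Going by the values given here, with no step between measured compounds, no direction can be read for this change in this assay; the one number, from compound 3, suggests the shared core sits in a weakly inhibiting range. Compound 4 is therefore expected near 8000 nM, estimated between 2500 nM and 30000 nM.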

Compound 4, half-maximal inhibitory concentration: 11300 nM
For compound 4 the middle estimate is 1.4-fold (0.15 log units) below the measured one, and the stated range covers the measured number.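

In this assay this position now has its first readable step, a 1.2-fold higher number from compound 3 to compound 4 (0.08 log units; within the scatter), with 4-chloro-3-nitrophenyl in place of 3-phenoxypropyl on a carbonyl carbon. Two quite different groups at this carbonyl therefore cannot be told apart on this read-out. The steps from compound 1 and compound 2 cannot be read, and no supporting data bear on this result.

Still open, going by these compounds, is whether an amine or a carboxylic acid on the phenyl ring at this carbonyl would give a step beyond the scatter.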